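The source may hold more compounds than are shown below. What is called first, only, known or untested is meant among the compounds shown, and "the series" means these compounds.

Compound 1 `Cn1cnc(S(=O)(=O)N2CC3CCC(NC(=O)c4ccc(Cl)cc4)C3C2)c1` gives 1030000 nM in an assay on isolated protein for inhibition of sodium- and chloride-dependent glycine transporter 1 (Homo sapiens); a higher number here means a weaker inhibitor, a lower number a stronger inhibitor.
Compound 2 `Cn1cnc(S(=O)(=O)N2CC(C(NC(=O)c3ccc(Cl)cc3Cl)c3ccccc3)C2)c1` gives 39000 nM in this assay.

Compound 2 has the lower of these two numbers, so within this pair it is the stronger inhibitor; the number for compound 1 is higher by a gap well outside the usual scatter. Among the measured compounds shown here, the two measured compounds differ in several places at once, so no single step between them can be isolated, and nothing here shows how any one group affects the read-out on its own.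

Compound 3 `Cn1cnc(S(=O)(=O)N2CC(C(NC(=O)c3ccc(Cl)cc3Cl)c3cccs3)C2)c1` is an unmeasured close relative of compound 2. For the measured compounds named here, the only change is thiophen-2-yl in place of phenyl on a saturated chain carbon bound to an amide-type nitrogen and a saturated ring carbon. Going by the values given here, a swap of this kind between two small aromatic rings often leaves the read-out roughly where it was, and no measured pair here argues otherwise. The step from compound 2 to compound 3 is therefore expected to be small, a 1.1-fold lower number from compound 2 to compound 3 (0.05 log units; within the scatter), in no clear direction beyond the scatter. For compound 3 the estimate in this assay is 35000 nM, with a range from 10000 nM to 120000 nM.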

Compound 3, half-maximal inhibitory concentration: 40000 nM
Estimate against measurement, compound 3: 1.1-fold (0.06 log units) below; measured number inside the range.
By their numbers in this assay, from the lowest: compounds 2 and 3 (each within the scatter of the next); then compound 1.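

Read in this assay, thiophen-2-yl in place of phenyl on a saturated chain carbon bound to an amide-type nitrogen and a saturated ring carbon gives a 1.0-fold higher number from compound 2 to compound 3 (0.01 log units; within the scatter), and this is the first comparison here in which only one place differs. At this place, the two aromatic rings cannot be told apart by the read-out, even though the entering ring has a sulfur atom and a hydrogen-bond acceptor that the leaving ring lacks. No independent measurement is available to explain this result.

The compounds shown leave open whether this place accepts groups other than these two small aromatic rings, such as a saturated cyclohexyl ring, a small methyl group or a pyridine ring. They also leave open whether an amine at this place would change the read-out.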